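This account rests on a few compounds, and the source may have more. Where it says the series, first, only, none or still open, it means among the compounds named here.

Of the compounds shown here, three built on one shared core have been tested in a functional assay on HEK293 cells for agonist activity at G-protein coupled receptor 39 (Mus musculus), read by inositol phosphate accumulation; a lower number here means that less compound is needed, a higher number that more compound is needed for the effect. Compound 1 `CNc1nc(NCc2ccc(OC(F)(F)F)cc2)cc(-c2ccccn2)n1` gives 7 nM. Compound 2 `CNc1nc(NCc2ccc(S(C)(=O)=O)cc2)cc(-c2ccccn2)n1` gives 185 nM. Compound 3 `CNc1nc(NCc2ccc(NC(C)=O)cc2)cc(-c2ccccn2)n1` gives 2 nM, the lowest of the three numbers, and both of its steps to the others lie beyond the scatter: a 3.5-fold lower number from compound 1 to compound 3 (0.54 log units; beyond the scatter) and a 93-fold lower number from compound 2 to compound 3 (1.97 log units; beyond the scatter). So the group at this position on the outer ring moves the read-out strongly, in both directions.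

Compound 4 `CNC(=O)c1ccc(CNc2cc(-c3ccccn3)nc(NC)n2)cc1` takes the next step from compound 3: methylcarbamoyl in place of acetamido on an aromatic carbon. The two groups are made of the same atoms, joined differently, each with one hydrogen-bond donor and one hydrogen-bond acceptor, so this exchange is gentler than either measured exchange at this position. The measured steps show how much room there is, but none of them swaps two such similar groups. The step from compound 3 to compound 4 is expected to be small, most likely a slight rise: a 3.0-fold higher number from compound 3 to compound 4 (0.48 log units; beyond the scatter). Compound 4 is therefore expected to give about 6 nM, within a range from 1.5 nM to 25 nM.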

Compound 4, half-maximal effective concentration: 8 nM
The estimate for compound 4 lay 1.3-fold (0.12 log units) below the measured number; the measured number falls inside the stated range.
By their numbers in this assay, from the lowest: compound 3; then compounds 1 and 4 (each within the scatter of the next); then compound 2.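

Joining the same atoms the other way round is not a silent change at this position: in this assay there is a 4.0-fold higher number from compound 3 to compound 4 (0.60 log units; beyond the scatter) even though the counted donors and acceptors stay the same. The methylcarbamoyl group also keeps the number far from that of the methylsulfonyl group, with a 23-fold lower number from compound 2 to compound 4 (1.36 log units; beyond the scatter) on that exchange. Against trifluoromethoxy there is a 1.1-fold higher number from compound 1 to compound 4 (0.06 log units; within the scatter) and so no difference can be claimed, which means that two groups of quite different atoms can give matching numbers here, and no measurement at hand explains these steps.

On these data alone, whether an amine or a carboxylic acid at this position would keep the number this low remains open. So does whether a longer chain on the amide nitrogen, such as ethylcarbamoyl, would hold it there.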